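Swapping oxan-4-yl for 3-(trifluoromethyl)phenyl

A few compounds are considered here, and "the series" means these few. Any claim that something is new, unique, unknown or untested is made for them only; others in the source may bear on it.

In a physicochemical assay for solubility, using the shake flask method, in simulated intestinal fluid, measured as kinetic solubility, with a stated time of 2 h, at 25 degrees C, at pH 6.5 (on this read-out lower numbers stand for lower solubility and higher numbers for higher solubility), compound 1 (`Cc1nc(C#N)c(N)c2c1C(=O)N(Cc1ccccc1)C2=O`) gives < 5000 nM as its result, which is a limit and not a number. Compound 2 (`Cc1nc(C(=O)OC2CC2)c(N)c2c1C(=O)N(Cc1ccccc1)C2=O`) reads 202000 nM in the same test. Going by the values given here, the one measured step is an at least 40-fold higher number from compound 1 to compound 2 (1.60 log units; beyond the scatter) and it is large, yet it lies at an aromatic carbon and shows only how far these numbers can move. Compound 3 (`Cc1noc(-c2nc(C)c3c(c2N)C(=O)N(CC2CCOCC2)C3=O)n1`) gives 5700 nM as the lower of the two actual numbers. Among the compounds with values here, compound 4 (`Cc1noc(-c2nc(C)c3c(c2N)C(=O)N(Cc2cccc(C(F)(F)F)c2)C3=O)n1`) differs from it by 3-(trifluoromethyl)phenyl in place of oxan-4-yl on a saturated chain carbon bound to an amide-type nitrogen in a ring as its single change, and no measured step touches that place. Only a small shift to a lower number is therefore expected, namely a 2.3-fold lower number from compound 3 to compound 4 (0.36 log units; beyond the scatter) as an estimate. Compound 4 is expected at 2500 nM in this assay (500 nM to 10000 nM) and may be reported only as a limit.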

Compound 4, solubility: < 5000 nM
Compound 4 ended at the assay's limit; the forecaster's own chance of this, stated with the estimate: 60%; the middle value does not contradict the limit.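

The step at this place, on a saturated chain carbon bound to an amide-type nitrogen in a ring, is an at least 1.1-fold lower number from compound 3 to compound 4 (0.05 log units; that floor lies within the scatter). With 3-(trifluoromethyl)phenyl in place of oxan-4-yl, that floor shows no change beyond the scatter in this assay. Compound 4 gives < 5000 nM, which is a limit and not a number: the limit of < 5000 nM in this assay, at which 2 of the 4 values shown sit.

Going by these compounds, how far the true reading of compound 4 lies from that of compound 3 stays open. Also open, on these data alone, is how an amine or a longer chain in place of oxan-4-yl would read in this assay.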